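This account rests on a few compounds, and the source may have more. Where it says the series, first, only, none or still open, it means among the compounds named here.

Measured compounds:
- compound 1 `Cc1cccc(-c2n[nH]cc2N2CCCNCC2)c1`; in an assay on isolated protein for binding affinity to 5-hydroxytryptamine receptor 3A (Homo sapiens) (a lower number here means a stronger inhibitor, a higher number a weaker inhibitor), compound 1 gives 816 nM
- compound 2 `Fc1cccc(-c2n[nH]cc2N2CCCNCC2)c1`; compound 2 gives 656 nM
- compound 3 `COc1cccc(-c2n[nH]cc2N2CCCNCC2)c1`; compound 3 gives 1030 nM

Among these three numbers, compound 1 stands second highest, and all three lie close together: the step of a 1.2-fold lower number from compound 1 to compound 2 (0.09 log units; within the scatter) and the step of a 1.3-fold higher number from compound 1 to compound 3 (0.10 log units; within the scatter) are both within the scatter, as is the step of a 1.6-fold higher number from compound 2 to compound 3 (0.20 log units; within the scatter). Compound 4 `c1ccc(-c2n[nH]cc2N2CCCNCC2)cc1` differs from compound 1 by hydrogen in place of methyl on an aromatic carbon. Among the measured compounds shown here, no measured step removes a group outright; the three measured changes at this place exchange one group for another, and none moved the number beyond the scatter. The step to compound 4 is therefore expected to be small, with no clear direction, and compound 4 is estimated at 800 nM (range 350 nM to 1900 nM), which is a step of a 1.0-fold lower number from compound 1 to compound 4 (0.01 log units; within the scatter).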

Compound 4, inhibition constant: 2100 nM
The estimate for compound 4 lay 2.6-fold (0.42 log units) below the measured number; the whole stated range lies below it.
By their numbers in this assay, from the lowest: compounds 2, 1 and 3 (each within the scatter of the next); then compound 4.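

Taking the group away does what swapping it did not: hydrogen gives a higher number than methyl (a 2.6-fold higher number from compound 1 to compound 4 (0.41 log units; beyond the scatter)), than fluoro (a 3.2-fold higher number from compound 2 to compound 4 (0.51 log units; beyond the scatter)) and than methoxy (a 2.0-fold higher number from compound 3 to compound 4 (0.31 log units; beyond the scatter)). Among these compounds, then, having one of these three groups on this aromatic carbon matters more than which one it is, since those three stay within the scatter of each other. Nothing shown here explains this. Going by these compounds, whether an amine, a carboxylic acid or a longer chain on this carbon would keep the lower numbers remains open.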